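The source may report more compounds than this note shows. Statements on the series, on what has been measured and on what is new or still open speak of the compounds shown alone.

Three compounds have so far been measured in a functional assay on cells for agonist activity at Free fatty acid receptor 1 (Homo sapiens), read by FLIPR and calcium flux; on this read-out lower numbers stand for an effect already at smaller amounts and higher numbers for an effect only at larger amounts of compound:

compound 1, `CC#C[C@@H](Cc1nnn[nH]1)c1ccc(OCc2ccc3scc(-c4cc(OCCOC)ccc4C)c3c2)cc1`, gives 85 nM
compound 2, `CC#C[C@@H](Cc1nnn[nH]1)c1ccc(OCc2ccc3scc(C4CCCCC4)c3c2)cc1`, gives 107 nM
compound 3, `CC#C[C@@H](Cc1nnn[nH]1)c1ccc(OCc2ccc3scc(-c4cncnc4C)c3c2)cc1`, gives 37 nM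

Compound 3 stands lowest of the three numbers. Its nearest neighbour is compound 1, the step of a 2.3-fold lower number from compound 1 to compound 3 (0.36 log units; beyond the scatter) lying beyond the scatter, and the step of a 2.9-fold lower number from compound 2 to compound 3 (0.46 log units; beyond the scatter) is larger still. Between compound 1 and compound 2 the step of a 1.3-fold higher number from compound 1 to compound 2 (0.10 log units; within the scatter) is within the scatter.

Compound 4, `CC#C[C@@H](Cc1nnn[nH]1)c1ccc(OCc2ccc3scc(C4CC4)c3c2)cc1`, has not yet been measured. It differs from compound 3 in one place: cyclopropyl in place of 4-methylpyrimidin-5-yl on an aromatic carbon. The step that bears most directly on this change is a 2.9-fold lower number from compound 2 to compound 3 (0.46 log units; beyond the scatter), in which a saturated carbon ring gave way to the 4-methylpyrimidin-5-yl group and the number fell modestly. Within the data shown here, compound 4 carries a saturated carbon ring again, so the reverse of that step is the guide, although no measured pair shows how cyclopropyl compares with cyclohexyl. Compound 4 is therefore expected to give a higher number than compound 3, a step of about a 2.7-fold higher number from compound 3 to compound 4 (0.43 log units; beyond the scatter). In this assay compound 4 is estimated at 100 nM, with a range from 40 nM to 250 nM.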

Compound 4, half-maximal effective concentration: 858 nM
Compound 4: the middle estimate sits 8.6-fold (0.93 log units) below what was measured; the whole stated range lies below it.
By their numbers in this assay, from the lowest: compound 3; then compounds 1 and 2 (each within the scatter of the next); then compound 4.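

In this assay, among these compounds, this position, on an aromatic carbon two ring bonds from the ring sulfur, turns out to be far more sensitive than the modest steps among the earlier compounds suggested: replacing 4-methylpyrimidin-5-yl with cyclopropyl gives the largest step so far (a 23-fold higher number from compound 3 to compound 4 (1.37 log units; beyond the scatter)). A saturated carbon ring as such does not set the number, as cyclopropyl in place of cyclohexyl also gives a clear rise (an 8.0-fold higher number from compound 2 to compound 4 (0.90 log units; beyond the scatter)). The aryl group carrying the 2-methoxyethoxy chain likewise gives way to cyclopropyl with a clear rise (a 10-fold higher number from compound 1 to compound 4 (1.00 log units; beyond the scatter)).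

No measurement shown here explains the rise. From the compounds shown here alone, whether a cyclobutyl or cyclopentyl ring, or an open isopropyl chain, would bring the number back towards that of cyclohexyl remains open.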